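(4-Methylphenyl)sulfanyl in place of sulfonyl in compound 3

The compounds below may be only part of what the source reports. "The series", "measured", "known", "first", "only" and "open" are said of these compounds alone.

Measured so far in a functional assay on DU-145 cells (Homo sapiens) for inhibition, read by trypan blue exclusion, with a stated time of 96 h; on this read-out higher numbers stand for weaker inhibition of growth and lower numbers for stronger inhibition of growth
- compound 1 `Cc1ccc(CS(=O)(=O)/C(=C/c2ccc(Br)cc2)C(=O)c2ccc(Cl)cc2)cc1` (25000 nM)
- compound 2 `CCOc1ccc(/C=C(/Sc2ccccc2Cl)C(=O)c2ccc(Cl)cc2)cc1OC` (50000 nM)
- compound 3 `CCOc1ccc(/C=C(\C(=O)c2ccc(Cl)cc2)S(=O)(=O)Cc2ccc(C)cc2)cc1OC` (10000 nM)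

Compound 3 holds the lowest number of the three, and its steps to both others lie beyond the scatter. Compound 4 `CCOc1ccc(/C=C(/Sc2ccc(C)cc2)C(=O)c2ccc(Cl)cc2)cc1OC` has not yet been measured. It has (4-methylphenyl)sulfanyl in place of (4-methylbenzyl)sulfonyl on a double-bonded chain carbon bound to a carbonyl carbon and a double-bonded chain carbon.

For the measured compounds named here, the step that bears most directly on this change is the one with compound 2 (a 5.0-fold lower number from compound 2 to compound 3 (0.70 log units; beyond the scatter)), which is modest and exchanges a sulfanyl group for the same sulfonyl group at that place. The step with compound 1 (a 2.5-fold lower number from compound 1 to compound 3 (0.40 log units; beyond the scatter)) concerns another part of the molecule and says little here. No measurement compares the two sulfanyl groups. A modest rise in this assay is therefore expected, of about the size seen with compound 2.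

The estimated change is (a 3.5-fold higher number from compound 3 to compound 4 (0.54 log units; beyond the scatter)).

Compound 4 is expected at 35000 nM (estimated range 12000 nM to 100000 nM).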

Compound 4, concentration for 50% growth inhibition: 25000 nM
Estimate against measurement, compound 4: 1.4-fold (0.15 log units) above; the measured number falls inside the stated range.
By their numbers in this assay, from the lowest: compound 3; then compounds 1, 4 and 2 (each within the scatter of the next).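

In this assay the exchange of (4-methylbenzyl)sulfonyl for (4-methylphenyl)sulfanyl gives a 2.5-fold higher number from compound 3 to compound 4 (0.40 log units; beyond the scatter) and so shows that compound 3 also keeps the lower number against a sulfanyl compound carrying no chlorine on its sulfur-bound ring. The other new comparison, a 2.0-fold lower number from compound 2 to compound 4 (0.30 log units; within the scatter) for 4-methylphenyl in place of 2-chlorophenyl on the sulfur, shows that these two sulfanyl groups are not separated in this read-out. Nothing measured here accounts for the difference between the sulfonyl and sulfanyl compounds.

The compounds shown leave open whether the step from compound 3 to compound 4 belongs to the sulfonyl or to the benzyl part of the group, which a (4-methylphenyl)sulfonyl group at this place would separate. They also leave open how an amine or a carboxylic acid on the sulfur-bound ring would read.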